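A Methyl Added to a Weak Inhibitor

The source may report more compounds than this note shows. Statements on the series, on what has been measured and on what is new or still open speak of the compounds shown alone.

Compound 1 `COc1ccccc1-c1cc(O)c2cccnc2n1`, compound 2 `COc1cccc(-c2cc(O)c3c(C)ccnc3n2)c1` and compound 3 `COc1cccc(-c2cc(O)c3cccnc3n2)c1` were tested in a functional assay on MDA-N cells (Homo sapiens); a higher number here means a weaker inhibitor of growth, a lower number a stronger inhibitor of growth. In this assay, going by the values given here, compound 1 gives 20000 nM, the only full number among the three. For compound 2 the result in this assay is a limit of the assay, < 10 nM. For compound 3 the result in this assay is likewise a limit, < 10 nM. Compound 3 and compound 2 differ by methyl in place of hydrogen on an aromatic carbon, and the step that the two limits leave unreadable from compound 3 to compound 2 has no readable size, as the limit of < 10 nM in this assay, at which 2 of the 3 values shown sit, covers both. Compound 1 and compound 3 have the same atoms joined differently; the difference between the two cores is not broken down here. Compound 4 `COc1ccccc1-c1cc(O)c2cc(C)cnc2n1`, not yet measured, arises from compound 1 by methyl in place of hydrogen on an aromatic carbon, the same kind of change as from compound 3 to compound 2, though the place differs: there the carbon is ortho to a fused ring and opposite the ring nitrogen, here it is two atoms from the ring nitrogen and para to a fused ring. With no measured size for this kind of change, the expected step of a 1.3-fold lower number from compound 1 to compound 4 (0.12 log units; within the scatter) in this assay is kept modest, resting on compound 1 at 20000 nM. Compound 4 is therefore estimated at about 15000 nM in this assay, expected between 4000 nM and 60000 nM.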

Compound 4, concentration for 50% growth inhibition: 4470 nM
Beside the measured number, compound 4's estimate is 3.4-fold (0.53 log units) above it; the range from low to high includes it.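

On the core of compound 1, methyl in place of hydrogen on an aromatic carbon two atoms from the ring nitrogen gives in this assay a 4.5-fold lower number from compound 1 to compound 4 (0.65 log units; beyond the scatter), so on this core the change has a readable effect, though a single pair. The same kind of change on the other core cannot be read, and there the methyl stands at a different place, so this pair gives no size that can be carried from one core to the other, and compound 2 and compound 3 both rest on a limit of the assay: the limit of < 10 nM in this assay, at which 2 of the 4 values shown sit. One pair therefore does not show whether the step depends on the core or on the place of the methyl, and it gives no reason for the step.

The compounds shown leave open whether an ethyl group or an amine on that same carbon of the core of compound 1 would move the number further. They also leave open whether methyl on another carbon of that core would give a step of similar size.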